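The compounds below may be only part of what the source reports. "The series", "measured", "known", "first", "only" and "open" are said of these compounds alone.

In an ADME assay on MRC5 cells (Homo sapiens), read by MTT assay, with a stated time of 3 days (on this read-out lower numbers stand for stronger inhibition and higher numbers for weaker inhibition), two compounds sharing one core have been measured so far. Compound 1 `CNc1ncnc2[nH]cc(Sc3cccs3)c12` gives 148000 nM, and compound 2 `Cc1ncnc2[nH]cc(Sc3cccs3)c12` gives 136000 nM. Within the data shown here, compound 2 therefore stands level with compound 1, as the only measured step shows: a 1.1-fold lower number from compound 1 to compound 2 (0.04 log units; within the scatter). That step put methyl in place of methylamino on an aromatic carbon.

Compound 3 `COc1ncnc2[nH]cc(Sc3cccs3)c12` keeps the core but has methoxy in place of methyl on an aromatic carbon, next to the ring nitrogen: methoxy in place of methyl on an aromatic carbon. Among the measured compounds shown here, one measured step is thin evidence, and no methoxy compound has yet been tested here. Still, the swap that gave compound 2 left the number almost unmoved, a 1.1-fold lower number from compound 1 to compound 2 (0.04 log units; within the scatter), so no change beyond the scatter is expected in this assay. The expected step is a 1.0-fold lower number from compound 2 to compound 3 (0.02 log units; within the scatter). For compound 3, the estimated value is 130000 nM, with an expected range from 60000 nM to 260000 nM.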

Compound 3, half-maximal inhibitory concentration: 148000 nM
Beside the measured number, compound 3's estimate is 1.1-fold (0.06 log units) below it; measured number inside the range.
By their numbers in this assay, from the lowest: compounds 2, 1 and 3 (each within the scatter of the next).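

In this assay, methoxy in place of methyl gives a 1.1-fold higher number from compound 2 to compound 3 (0.04 log units; within the scatter) at this aromatic carbon, and methoxy in place of methylamino gives no change at the digits printed from compound 1 to compound 3 (within the scatter) on the same carbon. One swap at this position had been read before; the three groups can now be compared with one another, and all three numbers lie within the scatter, even though methoxy brings an oxygen and a hydrogen-bond acceptor that methyl lacks. Nothing measured here offers an explanation for these level numbers.

From the compounds shown here alone, all three groups are small, so it remains open whether a carboxylic acid, a longer chain such as butyl, or a phenyl ring at this carbon would move the number beyond the scatter. The compounds also leave open whether changes elsewhere on the shared core would do so.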